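A nitrophenyl exchange in a weakly antiproliferative series

The source may report more compounds than this note shows. Statements on the series, on what has been measured and on what is new or still open speak of the compounds shown alone.

Measured in a functional assay on MCF7 cells (Homo sapiens) for antiproliferative activity, read by MTT assay; a higher number here means a weaker inhibitor, a lower number a stronger inhibitor:
- compound 1 `CC1(C)CCc2cc(C(=O)/C=C/c3ccc(OCc4cn(-c5ccc(Cl)cc5)nn4)cc3)c(O)cc2O1`: "not active" (no number reported)
- compound 2 `CC1(C)CCc2cc(C(=O)/C=C/c3ccc(OCc4cn(-c5ccc(Br)cc5)nn4)cc3)c(O)cc2O1`: "not active" (no number reported)
- compound 3 `Cc1c(-n2cc(COc3ccc(/C=C/C(=O)c4cc5c(cc4O)OC(C)(C)CC5)cc3)nn2)cccc1[N+](=O)[O-]`: 176000 nM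

Of these three, only compound 3 carries a number (176000 nM), and the other two were reported without one. Compound 4 `COc1ccc(-n2cc(COc3ccc(/C=C/C(=O)c4cc5c(cc4O)OC(C)(C)CC5)cc3)nn2)c([N+](=O)[O-])c1` has not yet been measured. It differs from compound 3 in one place, with 4-methoxy-2-nitrophenyl in place of 2-methyl-3-nitrophenyl on an aromatic nitrogen of a five-membered aromatic ring with 3 nitrogen (4-methoxy-2-nitrophenyl in place of 2-methyl-3-nitrophenyl on an aromatic nitrogen). Among the measured compounds shown here, no step between measured compounds exists to show how much such a change can move this assay. The expectation therefore rests on the value of compound 3 (176000 nM). The results for compound 1 ("not active" (no number reported)) and compound 2 ("not active" (no number reported)) leave open that compound 4 also returns no number. The expected step of a 1.0-fold lower number from compound 3 to compound 4 (0.02 log units; within the scatter) is none beyond the usual scatter, in neither direction. If a number is reported, the estimate for compound 4 is 170000 nM (expected range 60000 nM to 450000 nM).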

Compound 4, half-maximal inhibitory concentration: "not active" (no number reported)
For compound 4 the study gives words and no number; there is nothing to compare the estimate with.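

In this assay compound 3 gives 176000 nM and compound 4 gives "not active" (no number reported), so no step can be read between them. The compounds shown leave open how far 4-methoxy-2-nitrophenyl in place of 2-methyl-3-nitrophenyl moves this read-out. No measurement shown bears on this result.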